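Methoxy for bromo on the sulfonyl aryl of the series

This account rests on a few compounds, and the source may have more. Where it says the series, first, only, none or still open, it means among the compounds named here.

Three compounds of the series are measured in a functional assay on DU-145 cells (Homo sapiens) for inhibition, read by trypan blue exclusion, with a stated time of 96 h; on this read-out lower numbers stand for stronger inhibition of growth and higher numbers for weaker inhibition of growth. Compound 1 `O=C(/C(=C\c1ccccc1OCc1ccccc1)S(=O)(=O)c1ccc(Br)cc1)c1ccc(Cl)cc1` gives 1000 nM. Compound 2 `Cc1ccc(S(=O)(=O)/C(=C/c2ccc(Br)cc2)C(=O)c2ccc(Br)cc2)cc1` gives 10000 nM, and compound 3 `COc1ccc(/C=C(\C(=O)c2ccc(Br)cc2)S(=O)(=O)c2ccc(C)cc2)cc1` gives 1000 nM. Compound 3 differs from compound 2 by methoxy in place of bromo on an aromatic carbon, a change that brought a 10-fold lower number from compound 2 to compound 3 (1.00 log units; beyond the scatter). The difference between the cores of compound 1 and compound 2 is not broken down here. Compound 4 `COc1ccc(S(=O)(=O)/C(=C/c2ccccc2OCc2ccccc2)C(=O)c2ccc(Cl)cc2)cc1` carries the same change relative to compound 1, (methoxy in place of bromo on an aromatic carbon), though one bond further out it reads (4-bromophenyl)sulfonyl to (4-methoxyphenyl)sulfonyl, so the aryl that bears it is a different one. The step is therefore expected to be smaller than the measured one, about a 2.0-fold lower number from compound 1 to compound 4 (0.30 log units; within the scatter), resting on compound 1 at 1000 nM. Compound 4 is estimated at 500 nM, within 150 nM to 2000 nM.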

Compound 4, concentration for 50% growth inhibition: 1000 nM
Estimate against measurement, compound 4: 2.0-fold (0.30 log units) below; the measured number falls inside the stated range.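

In this assay, methoxy in place of bromo on the sulfonyl aryl brings no change at the digits printed from compound 1 to compound 4 (within the scatter), and the two steps for this change differ: the same change on two cores in this assay, a 10-fold lower number (1.00 log units; beyond the scatter) from compound 2 to compound 3 and no change at the digits printed (within the scatter) from compound 1 to compound 4, 10-fold (1.00 log units) apart, beyond the scatter of two such steps

The size of the step therefore does not carry as a fixed amount from one core to the other in this series. It does not show what sets the difference, since the aryl bearing the change is not the same in the two pairs and the cores differ elsewhere too, so two pairs cannot separate aryl from core.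

Still open, on these data alone, is how an amine or a carboxylic acid in place of bromo on the aryl sulfonyl of compound 1 would read. Also open, as far as these compounds go, is whether the step holds on further cores.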